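Working notes: from compound 2 to compound 4

This account rests on a few compounds, and the source may have more. Where it says the series, first, only, none or still open, it means among the compounds named here.

Measured in a functional assay on MDA-MB-436 cells (Homo sapiens) for antiproliferative activity, read by MTT assay, with a stated time of 24 h; a higher number here means a weaker inhibitor, a lower number a stronger inhibitor:
- compound 1 `O=C(O)CC(NS(=O)(=O)c1ccccc1Br)c1ccccc1` gives > 100000 nM (a limit)
- compound 2 `CC(C)(C)c1ccc(C(CC(=O)O)NC(=O)c2ccc(F)cc2)cc1` gives > 100000 nM (a limit)
- compound 3 `CC(C)(C)c1ccc(C(CC(=O)O)NC(=O)c2ccc(C(F)(F)F)cc2)cc1` gives 82300 nM

Compound 2 stands only at a limit of this assay, namely > 100000 nM. Compound 1 sits at the same limit, which makes this (the limit of > 100000 nM in this assay, at which 2 of the 3 values shown sit). No number therefore anchors the starting point of the step.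

Compound 4 `CC(C)(C)c1ccc(C(CC(=O)O)NC(=O)c2c(Cl)cccc2Cl)cc1` carries 2,6-dichlorophenyl in place of 4-fluorophenyl on a carbonyl carbon, and the count of that change is 2,6-dichlorophenyl in place of 4-fluorophenyl on a carbonyl carbon.

For the measured compounds named here, one measured step bears on this change only in part. It is an at least 1.2-fold lower number from compound 2 to compound 3 (0.08 log units; that floor lies within the scatter), and it alters a substituent on the aromatic ring without replacing the ring as a whole. Going by the values given here, compound 3 , at 82300 nM, supplies the only true number. Neither gives grounds to expect a step beyond the scatter, so compound 4 is expected to stay close to the limit, and a report of the limit alone is about as likely as a number. The estimated change is an at least 1.2-fold lower number from compound 2 to compound 4 (0.09 log units; that floor lies within the scatter). For compound 4 the expected value is 80000 nM, with an estimated range from 30000 nM to 150000 nM.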

Compound 4, half-maximal inhibitory concentration: > 100000 nM
Compound 4 gave a limit, no number; the forecaster's own chance of this, stated with the estimate: 50%; middle value at least 1.2-fold (0.09 log units) away from the limit.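

No step can be read from compound 2 to compound 4, because both compounds stand at the same limit rather than at a number: the limit of > 100000 nM in this assay, at which 3 of the 4 values shown sit.

The compounds shown leave open whether 2,6-dichlorophenyl in place of 4-fluorophenyl on a carbonyl carbon changes the antiproliferative read-out at all, and in which direction.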